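The source may report more compounds than this note shows. Statements on the series, on what has been measured and on what is new or still open speak of the compounds shown alone.

Three compounds have been measured in a functional assay on U2OS cells (Homo sapiens) for antiproliferative activity, read by MTT assay, with a stated time of 72 h; on this read-out higher numbers stand for weaker inhibition and lower numbers for stronger inhibition:
compound 1 `CC(C)OC1=C(C(=O)c2ccccc2)C(c2ccc(Br)cc2)N(CCCn2ccnc2)C1=O`, 24800 nM
compound 2 `NC1=C(C(=O)c2ccccc2)C(c2ccc(Br)cc2)N(CCCn2ccnc2)C1=O`, 149000 nM
compound 3 `O=C(C1=C(Nc2ccc(F)cc2)C(=O)N(CCCn2ccnc2)C1c1ccc(Br)cc1)c1ccccc1`, 30000 nM

Compound 3 stands second highest of the three: its number lies within the scatter of compound 1, while compound 2 lies further away, as shown by a 5.0-fold lower number from compound 2 to compound 3 (0.70 log units; beyond the scatter). Compound 4 `O=C(C1=C(NCc2ccccc2)C(=O)N(CCCn2ccnc2)C1c1ccc(Br)cc1)c1ccccc1` differs from compound 3 in one place: benzyl in place of 4-fluorophenyl on an amine nitrogen. Among the measured compounds shown here, two measured steps touch this amine nitrogen. a 5.0-fold lower number from compound 2 to compound 3 (0.70 log units; beyond the scatter) shows a modest lowering when a ring-bearing group replaced hydrogen there, and a 1.2-fold higher number from compound 1 to compound 3 (0.08 log units; within the scatter) shows that the arylamino and isopropoxy forms gave numbers within the scatter. For the measured compounds named here, no measured compound carries a benzyl group, so there is no direct guide. Since compound 4 keeps a ring-bearing group on that nitrogen, the step of no change at the digits printed from compound 3 to compound 4 (within the scatter) is expected to remain within the scatter. The estimate for compound 4 is 30000 nM, ranging from 10000 nM to 90000 nM.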

Compound 4, half-maximal inhibitory concentration: 32500 nM
For compound 4 the middle estimate is 1.1-fold (0.03 log units) below the measured one, and the stated range covers the measured number.
By their numbers in this assay, from the lowest: compounds 1, 3 and 4 (each within the scatter of the next); then compound 2.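

In this assay benzyl in place of 4-fluorophenyl on the amine nitrogen gives a 1.1-fold higher number from compound 3 to compound 4 (0.03 log units; within the scatter), so these two ring-bearing groups cannot be told apart here. Benzyl also gives the modest lowering over the unsubstituted amino form, with a 4.6-fold lower number from compound 2 to compound 4 (0.66 log units; beyond the scatter), and a 1.3-fold higher number from compound 1 to compound 4 (0.12 log units; within the scatter) shows that benzylamino and isopropoxy cannot be told apart either. No measurement shown here explains these numbers. Going by these compounds, what remains open is whether this nitrogen needs a ring at all, which a simple alkyl group such as butyl on the nitrogen would help settle.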